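The source may report more compounds than this note shows. Statements on the series, on what has been measured and on what is new or still open speak of the compounds shown alone.

Measured so far:
compound 1 `CCc1cccc(NC(=O)CN2CCC(c3cccc[n+]3[O-])CC2)c1`, 95 nM
compound 2 `O=C(CN1CCC(c2cccc[n+]2[O-])CC1)Nc1ccc(F)cc1F`, 103 nM

In a functional assay on HEK293 cells for agonist activity at D(4) dopamine receptor (Homo sapiens), read by FLIPR (on this read-out lower numbers stand for an effect already at smaller amounts and higher numbers for an effect only at larger amounts of compound), compound 1 stands at the lower of the two numbers seen so far, and compound 2 gives a number that is not separable from it: a 1.1-fold higher number from compound 1 to compound 2 (0.04 log units; within the scatter). That single step swaps the whole aryl group on the amide nitrogen, 2,4-difluorophenyl for 3-ethylphenyl, and leaves the read-out where it was.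

Compound 3 `CC(C)Oc1cccc(NC(=O)CN2CCC(c3cccc[n+]3[O-])CC2)c1` keeps the shared core of compound 1 and differs from it in one place: isopropoxy in place of ethyl on an aromatic carbon. Among the measured compounds shown here, no measured step varies only the substituent on this ring, so the step from compound 1 to compound 2 is the only one that bears on the question, and it shows that a change of the amide-side aryl group can pass without a shift beyond the scatter. On that basis the expected step is a 1.2-fold higher number from compound 1 to compound 3 (0.06 log units; within the scatter), that is, no change beyond the scatter in either direction, with the range kept wide for want of a closer precedent. The estimate for compound 3 in this assay is 110 nM, expected between 40 nM and 320 nM.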

Compound 3, half-maximal effective concentration: 555 nM
For compound 3 the middle estimate is 5.0-fold (0.70 log units) below the measured one; measured number above the stated range.
By their numbers in this assay, from the lowest: compounds 1 and 2 (each within the scatter of the next); then compound 3.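

In this assay the substituent on this ring proves able to move the read-out: isopropoxy in place of ethyl on an aromatic carbon, meta to a large group, gives a 5.8-fold higher number from compound 1 to compound 3 (0.77 log units; beyond the scatter) in a step counted as modest but beyond the scatter. Among the compounds shown here, the only earlier step, a 1.1-fold higher number from compound 1 to compound 2 (0.04 log units; within the scatter), replaced the whole aryl group and stayed within the scatter, so that result cannot be taken to mean that changes on this ring pass without effect. The new step adds heavy atoms and a hydrogen-bond acceptor together, and nothing at hand separates these two changes or gives a reason for the shift.

The compounds shown leave open whether the higher number follows the ether oxygen or the branched isopropyl part, a question that methoxy or isopropyl at the same place would address. They also leave open whether the same step would appear with the substituents of compound 2 on the ring, and how a hydroxyl or an amine at this place would read.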